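Working notes: one aromatic substituent swap on the shared core

The source may report more compounds than this note shows. Statements on the series, on what has been measured and on what is new or still open speak of the compounds shown alone.

Measured so far:
- compound 1 `C=CC[C@H]1C[C@]2([C@@H](C)Cc3cc(OC)c(OC)cc3F)OCOC2=CC1=O`: 14 nM in a functional assay on M14 cells (Homo sapiens) for antiproliferative activity, with a stated time of 72 h; a lower number here means a stronger inhibitor, a higher number a weaker inhibitor
- compound 2 `C=CC[C@H]1C[C@]2([C@@H](C)Cc3cc(C#N)c(OC)cc3F)OCOC2=CC1=O`: 37 nM in this assay

Going by the values given here, of the two numbers so far, compound 2 stands highest; its nearest neighbour is compound 1, and the step between them, a 2.6-fold higher number from compound 1 to compound 2 (0.42 log units; beyond the scatter), is the only measured change at this position of the shared core. That step was modest but beyond the scatter.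

Compound 3 `C=CC[C@H]1C[C@]2([C@@H](C)Cc3cc(NC(C)=O)c(OC)cc3F)OCOC2=CC1=O` differs from compound 2 in one place: acetamido in place of cyano on an aromatic carbon.

Among the compounds with values here, no measured step involves an acetamido group, so nothing bears on the new group directly. Within the data shown here, the single step that bears on it at all is a 2.6-fold higher number from compound 1 to compound 2 (0.42 log units; beyond the scatter), which shows that exchanging the substituent at this position shifts this assay only modestly. A modest step is therefore expected for compound 3 as well, with its direction open and the middle of the range kept close to compound 2. On that basis compound 3 is estimated at 40 nM in this assay, within a range of 12 nM to 130 nM, which means an expected step of a 1.1-fold higher number from compound 2 to compound 3 (0.03 log units; within the scatter).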

Compound 3, half-maximal inhibitory concentration: 52 nM
Compound 3: middle estimate off by 1.3-fold (0.11 log units), on the low side, within the range that was stated.
By their numbers in this assay, from the lowest: compound 1; then compounds 2 and 3 (each within the scatter of the next).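

In this assay, the acetamido group and the nitrile cannot be told apart at this position, ortho to a methoxy group and para to a fluoro group (a 1.4-fold higher number from compound 2 to compound 3 (0.15 log units; within the scatter)). The entering group has more heavy atoms than cyano and adds a hydrogen-bond donor, yet this change stays within the scatter, so neither difference shows up as a separable shift among these compounds. Acetamido also gives a second comparison with the methoxy group of compound 1 (a 3.7-fold higher number from compound 1 to compound 3 (0.57 log units; beyond the scatter)), and compound 1 now has the lowest number of the three, with both of its steps beyond the scatter and both replacements modest in size; no measurement available here accounts for this.

The compounds shown leave open whether the similar numbers for the nitrile and the acetamido group would extend to an amine, a carboxylic acid or a longer acyl chain such as propionamido at this position. They also leave open whether an N-methylacetamido group, which lacks the amide hydrogen, would stay with these two groups or move toward compound 1 or away from it in this assay.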